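Methyl Added to a Side Chain: Cytotoxicity in RD Cells

A few compounds are considered here, and "the series" means these few. Any claim that something is new, unique, unknown or untested is made for them only; others in the source may bear on it.

Compound 1 `CCCc1ccc(-c2ccc3ncc(C(=O)OCC)cc3c2)cc1`: > 7400 nM
Compound 2 `CCCCc1ccc(-c2ccc3ncc(C(=O)OCC)cc3c2)cc1`: > 7400 nM
Compound 3 `Cc1nc(-c2cnc3ccc(-c4ccc(N)nc4)cc3c2)no1`: > 7400 nM

Of the compounds shown here, three have been tested in a functional assay on RD cells (Homo sapiens) for inhibition, read by luminescence and ATP content, with a stated time of 72 h; a lower number here means that less compound is tolerated, a higher number that more compound is tolerated. Compound 1 reaches only the limit of the assay, > 7400 nM. Compound 2 likewise stands at a limit, > 7400 nM. Compound 3 gives > 7400 nM, again a limit. The change from compound 1 to compound 2 is methyl in place of hydrogen on a saturated chain carbon, three bonds along the chain from an aromatic carbon, and its step, a step that the two limits leave unreadable from compound 1 to compound 2, cannot be read because of the limit of > 7400 nM in this assay, at which 3 of the 3 values shown sit.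

Compound 4 `CCc1nc(-c2cnc3ccc(-c4ccc(N)nc4)cc3c2)no1` is not yet measured. It differs from compound 3 by methyl in place of hydrogen on a saturated chain carbon bound to an aromatic carbon; this is the same kind of change as from compound 1 to compound 2, though the place differs: here the carbon is bound to an aromatic carbon, there it is three bonds along the chain from an aromatic carbon. The difference between the cores of compound 1 and compound 3 is not broken down here. For compound 4 a step that the limit leaves unreadable from compound 3 to compound 4 is expected, resting on compound 3 sitting at a limit with > 7400 nM. Compound 4 is therefore estimated at 9000 nM, between 4000 nM and 30000 nM.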

Compound 4, half-maximal cytotoxic concentration: > 66700 nM
Compound 4 ended at the assay's limit; the forecaster's own chance of this, stated with the estimate: 80%; middle value at least 7.4-fold (0.86 log units) away from the limit.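

For the compounds shown here, compound 3 and compound 4 both stand at limits in this assay, and no step between them can be read. The compounds shown leave open whether methyl in place of hydrogen on a saturated chain carbon shifts cytotoxicity at all.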